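Thiophene for Tolyl in a Boronic Acid Sulfonamide Series

The source may hold more compounds than are shown below. What is called first, only, known or untested is meant among the compounds shown, and "the series" means these compounds.

Compound 1 `Cc1ccc(S(=O)(=O)Nc2cc(SCCC(=O)N[C@@H](CC(C)C)B(O)O)c(O)c3ccccc23)cc1` gives 6940 nM in a functional assay on MCF7 cells (Homo sapiens) for antiproliferative activity, read by sulforhodamine B assay, with a stated time of 72 h; a lower number here means a stronger inhibitor, a higher number a weaker inhibitor. Compound 2 `CC(C)C[C@H](NC(=O)CCSc1cc(NS(=O)(=O)c2cccs2)c2ccccc2c1O)B(O)O` carries thiophen-2-yl in place of 4-methylphenyl on a sulfonyl sulfur, and the step of a 1.1-fold lower number from compound 1 to compound 2 (0.03 log units; within the scatter), so that compound 2 gives 6470 nM in this assay. Compound 3 `Cc1ccc(S(=O)(=O)Nc2cc(SC(C)C(=O)N[C@@H](CC(C)C)B(O)O)c(O)c3ccccc23)cc1` is built from the same atoms as compound 1, joined differently; the difference between the two cores is not broken down here. In this assay compound 3 gives 8610 nM, and its gap to each of the other two is within the scatter. Compound 4 `CC(C)C[C@H](NC(=O)C(C)Sc1cc(NS(=O)(=O)c2cccs2)c2ccccc2c1O)B(O)O` differs from compound 3 by thiophen-2-yl in place of 4-methylphenyl on a sulfonyl sulfur, the same change that separates compound 1 from compound 2. Because that change gave a 1.1-fold lower number from compound 1 to compound 2 (0.03 log units; within the scatter), the expected step is a 1.1-fold lower number from compound 3 to compound 4 (0.03 log units; within the scatter). Compound 4 is therefore estimated at 8000 nM, with a range from 4000 nM to 16000 nM.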

Compound 4, half-maximal inhibitory concentration: 14700 nM
Compound 4: middle estimate off by 1.8-fold (0.26 log units), on the low side; measured number inside the range.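

In this assay, setting thiophen-2-yl in place of 4-methylphenyl on the sulfonyl sulfur gives a 1.7-fold higher number from compound 3 to compound 4 (0.23 log units; within the scatter) on the second core. This does not show that the two steps are identical, nor that the change would behave the same way on any core beyond these two. Within these two pairs, the change carries from one core to the other without a difference that can be told from the scatter: the same change on two cores in this assay, a 1.1-fold lower number (0.03 log units; within the scatter) from compound 1 to compound 2 and a 1.7-fold higher number (0.23 log units; within the scatter) from compound 3 to compound 4, 1.8-fold (0.26 log units) apart, within the scatter of two such steps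

The compounds shown leave open whether other groups on the sulfonyl sulfur, such as furan-2-yl or a phenyl ring carrying a methoxy group, would follow the same pattern. They also leave open how the change would read with a carboxylic acid in place of the boronic acid.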